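The source may hold more compounds than are shown below. What is called first, only, known or untested is meant among the compounds shown, and "the series" means these compounds.

In a functional assay on LM7 cells (Homo sapiens) for antiproliferative activity, read by MTT assay, with a stated time of 72 h (on this read-out higher numbers stand for weaker inhibition and lower numbers for stronger inhibition), compound 2 `O=c1c(Cl)c(CSC(=S)N2CCCC2)oc2ccccc12` gives 1900 nM, and compound 1 `O=c1c(Cl)c(CSC(=S)N2CCCCC2)oc2ccccc12` gives 3300 nM. The difference between these two is piperidin-1-yl in place of pyrrolidin-1-yl on a thiocarbonyl carbon. That step, a 1.7-fold higher number from compound 2 to compound 1 (0.24 log units; within the scatter), counts as no real change, since the two values fall within the normal scatter of this kind of measurement.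

Compound 3 `CCOC(=O)c1cc(=O)c2cc(CSC(=S)N3CCCC3)ccc2o1` rests on a different core, and how that core differs from the core of compound 2 is not broken down here. In this assay, for the measured compounds named here, compound 3 gives 18000 nM, which is the highest of the three numbers measured so far, beyond the scatter from both compound 1 and compound 2.

Compound 4 `CCOC(=O)c1cc(=O)c2cc(CSC(=S)N3CCCCC3)ccc2o1` has not yet been measured. It differs from compound 3 by piperidin-1-yl in place of pyrrolidin-1-yl on a thiocarbonyl carbon, the same change that separates compound 2 from compound 1. Because that earlier step was only a 1.7-fold higher number from compound 2 to compound 1 (0.24 log units; within the scatter), the expected step here, a 1.5-fold higher number from compound 3 to compound 4 (0.18 log units; within the scatter), is of a similar small size, with the new ring adding little either way. On that basis compound 4 is estimated at 27000 nM in this assay, with a likely range from 12000 nM to 60000 nM.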

Compound 4, half-maximal inhibitory concentration: 16900 nM
Compound 4: the middle estimate sits 1.6-fold (0.20 log units) above what was measured, within the range that was stated.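

In this assay, putting piperidin-1-yl in place of pyrrolidin-1-yl on the thiocarbonyl carbon gives a 1.1-fold lower number from compound 3 to compound 4 (0.03 log units; within the scatter), which counts as no real change. The same swap also made no real change on the other core, so in these two pairs the result carries over from one core to the other, and the two steps do not differ: the same change on two cores in this assay, a 1.7-fold higher number (0.24 log units; within the scatter) from compound 2 to compound 1 and a 1.1-fold lower number (0.03 log units; within the scatter) from compound 3 to compound 4, 1.8-fold (0.27 log units) apart, within the scatter of two such steps. This shows only that going between these two rings leaves the number in place on both cores; two pairs cannot show that the result would hold on a third core, and a swap without a real effect says nothing about how a swap with a clear effect would carry over.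

The compounds shown leave open what happens when the group on the thiocarbonyl carbon is something other than these two rings, such as a morpholine ring, a piperazine ring or an open-chain diethylamino group. They also leave open whether any such group would act alike on both cores.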